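A few compounds are considered here, and "the series" means these few. Any claim that something is new, unique, unknown or untested is made for them only; others in the source may bear on it.

In a functional assay on MCF7 cells (Homo sapiens) for inhibition, read by MTT assay, with a stated time of 72 h (on this read-out lower numbers stand for stronger inhibition and higher numbers for weaker inhibition), compound 1 `CC(C)=CCC[C@H](C)c1ccc(C)c2c1OCN(CCCCC(=O)O)C2` gives only a limit, > 20000 nM.
In this assay compound 2 `CC(C)=CCC[C@H](C)c1ccc(C)c(CNCCCCC(=O)O)c1O` also gives only a limit, > 20000 nM.
In this assay compound 3 `CCOC(CCN1COc2c([C@@H](C)CCC=C(C)C)ccc(C)c2C1)OCC` gives 13200 nM.

The change from compound 1 to compound 3 is diethoxymethyl in place of 2-carboxyethyl on a saturated chain carbon, two bonds along the chain from an amine nitrogen in a ring, and it made an at least 1.5-fold lower number from compound 1 to compound 3 (0.18 log units; that floor lies within the scatter). The difference between the core of compound 1 and the core of compound 2 is not broken down here. Compound 4 `CCOC(CCNCc1c(C)ccc([C@@H](C)CCC=C(C)C)c1O)OCC` differs from compound 2 by diethoxymethyl in place of 2-carboxyethyl on a saturated chain carbon, two bonds along the chain from an amine nitrogen; the place differs from the earlier one only in that there the amine nitrogen is in a ring, so this is the same kind of change. Because (the limit of > 20000 nM in this assay, at which 2 of the 3 values shown sit), the step from compound 1 to compound 3 is known only as a floor. For compound 4 a step of an at least 1.4-fold lower number from compound 2 to compound 4 (0.15 log units; that floor lies within the scatter) is expected, resting on an at least 1.5-fold lower number from compound 1 to compound 3 (0.18 log units; that floor lies within the scatter). Compound 4 is therefore estimated at 14000 nM, within 5000 nM to 40000 nM.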

Compound 4, half-maximal inhibitory concentration: 10300 nM
Estimate against measurement, compound 4: 1.4-fold (0.13 log units) above, and the stated range covers the measured number.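

Putting diethoxymethyl in place of 2-carboxyethyl on the core of compound 2 gave an at least 1.9-fold lower number from compound 2 to compound 4 (0.28 log units; that floor lies within the scatter) in this assay. Set beside the same change on the core of compound 1, this is consistent with the change carrying from one core to the other, but it does not establish that it does: the same change on two cores in this assay, an at least 1.5-fold lower number (0.18 log units; that floor lies within the scatter) from compound 1 to compound 3 and an at least 1.9-fold lower number (0.28 log units; that floor lies within the scatter) from compound 2 to compound 4; the limit leaves it open whether they differ. Neither step has a known size, since each starts from a compound that reaches only a limit: the limit of > 20000 nM in this assay, at which 2 of the 4 values shown sit.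

The compounds shown leave open how an ester or an amide in place of the carboxylic acid would read on either core. They also leave open what a shorter chain carrying the diethoxymethyl group would do.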